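The source may hold more compounds than are shown below. What is called first, only, known or untested is meant among the compounds shown, and "the series" means these compounds.

Measured so far in this series:
compound 1 `NC(=O)[C@H]1O[C@@H](n2cc(Br)c(O)nc2=O)C[C@@H]1O`: 0%
compound 2 `N#C[C@H]1O[C@@H](n2cc(I)c(O)nc2=O)C[C@@H]1O`: 0%
compound 3 `COC(=O)[C@H]1O[C@@H](n2cc(F)c(O)nc2=O)C[C@@H]1O`: 32%

In a functional assay on CCRF S-180 cells (Mus musculus) for cytotoxicity, with a stated time of 42 h, tested at 400 uM (on this read-out lower numbers stand for less inhibition and higher numbers for more inhibition at the one concentration tested (going by the name of the read-out)), compound 2 gives 0%, level with compound 1 at the digits shown, the two together the lowest of the three numbers. Furthest from compound 2 stands compound 3, which gives 32%, a number higher by more than the usual scatter. Compound 4 `NC(=O)[C@H]1O[C@@H](n2cc(I)c(O)nc2=O)C[C@@H]1O` is not yet measured. It differs from compound 2 by carbamoyl in place of cyano on a saturated ring carbon. Among the compounds with values here, no measured pair isolates this change, so its size is unknown. Compound 1 carries carbamoyl at the same place and gives 0%, which gives no sign of inhibition at this concentration. The expected step of a number 3 percentage points higher from compound 2 to compound 4 (within the scatter) therefore lies within the scatter. Compound 4 is expected to give 3%, with a range from 0% to 15%.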

Compound 4, a percentage reported as inhibition, at one concentration (the size of the read-out at that concentration, not a potency): 0%
For compound 4 the middle estimate is 3 percentage points above the measured one; the measured number falls inside the stated range.
By their numbers in this assay, from the lowest: compounds 1, 2 and 4 (each within the scatter of the next); then compound 3.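

Carbamoyl in place of cyano on the saturated ring carbon now has a measured step in this assay, with iodo held constant: no change at the digits printed from compound 2 to compound 4 (within the scatter). Iodo in place of bromo on the aromatic carbon, with carbamoyl held constant, also has one: no change at the digits printed from compound 1 to compound 4 (within the scatter). No supporting data bear on why neither change separates these compounds.

Compound 3 at 32% differs from these compounds in more than one place, so its number cannot be assigned to either methoxycarbonyl or fluoro alone. From the compounds shown here alone, how a carboxylic acid or an aminomethyl group on the saturated ring carbon, or fluoro paired with carbamoyl, would read remains open.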